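A few compounds are considered here, and "the series" means these few. Any claim that something is new, unique, unknown or untested is made for them only; others in the source may bear on it.

Compound 1 `Cc1nnc(COc2cnn(C(C)(C)C)c(=O)c2Cl)o1` gives > 299000 nM in a functional assay on the whole organism for inhibition, with Mythimna separata as the target, with a stated time of 5 days (on this read-out lower numbers stand for an effect already at smaller amounts and higher numbers for an effect only at larger amounts of compound), and this is a limit of the assay rather than a number.
Compound 2 `Cc1cc(C)cc(-c2nnc(COc3cnn(C(C)(C)C)c(=O)c3Cl)o2)c1` gives > 299000 nM in this assay, again a limit and not a number.

Going by the values given here, the single step between the two measured compounds, a step that the two limits leave unreadable from compound 1 to compound 2, cannot be read, since both of its ends sit at a limit; the limit of > 299000 nM in this assay, at which 2 of the 2 values shown sit, is all that these measurements reveal. Among the compounds with values here, compound 2 therefore stands nowhere definite on the scale of this assay: it is known only that its value lies at that limit, and the same holds for compound 1.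

Compound 3 `CC(C)(C)n1ncc(OCc2nnc(-c3cccs3)o2)c(Cl)c1=O` differs from compound 2 by thiophen-2-yl in place of 3,5-dimethylphenyl on an aromatic carbon. No readable measured step bears on this change. Within the data shown here, the only step available is itself unreadable. Among the measured compounds shown here, no size or direction can thus be drawn from the data, and the sole guide is that both measured compounds sit at the limit. Compound 3 is therefore expected to sit at or near that same limit, with an estimated value of 400000 nM and a range from 150000 nM to 2000000 nM. This estimate means an expected step that the limit leaves unreadable from compound 2 to compound 3, none beyond the scatter, held with little confidence.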

Compound 3, half-maximal effective concentration: > 299000 nM
Compound 3 ended at the assay's limit; the forecaster's own chance of this, stated with the estimate: 80%; the middle value lies beyond the limit too.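

Compound 3 gives a limit of this assay rather than a number, as do compound 1 and compound 2, so no step among these three compounds can be read: the limit of > 299000 nM in this assay, at which 3 of the 3 values shown sit.

The compounds shown leave open whether swapping methyl, 3,5-dimethylphenyl and thiophen-2-yl on this aromatic carbon changes the effect at all, and how far past the limit each compound's true value lies.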